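This account rests on a few compounds, and the source may have more. Where it says the series, first, only, none or still open, it means among the compounds named here.

Compound 1 `ClC(Cl)(Cl)c1nc(-c2ccccc2)c2ccccc2n1`: > 500000 nM
Compound 2 `COc1cc(-c2nc(C(Cl)(Cl)Cl)nc3ccccc23)cc(OC)c1OC`: > 250000 nM

For the measured compounds named here, only two compounds have been measured so far, both in an ADME assay on THP-1 cells (Homo sapiens) for cytotoxicity, read by MTT assay; a higher number here means that more compound is tolerated, a lower number that less compound is tolerated. Compound 1 gives > 500000 nM. That value is a limit of the assay and not a number. Compound 2 gives > 250000 nM, which is also a limit. Going by the values given here, compound 1 therefore has no exact position on the scale, and the only other value available for comparison offers no exact number either.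

The next compound to be tested is compound 3 `Clc1ccc(-c2nc(C(Cl)(Cl)Cl)nc3ccccc23)cc1`. It differs from compound 1 by a single change: chloro in place of hydrogen on an aromatic carbon. In words, this is chloro in place of hydrogen on an aromatic carbon, so that phenyl becomes 4-chlorophenyl. Among the compounds with values here, no measured pair of compounds shows what a single change does in this assay, so any forecast is loose. A modest move towards less compound being tolerated seems the likeliest outcome, though no change beyond the scatter is also possible, and another limit would be no surprise. The estimated change is an at least 2.0-fold lower number from compound 1 to compound 3 (0.30 log units; that floor lies within the scatter). Compound 3 is expected to give 250000 nM, with an estimated range from 60000 nM to 500000 nM.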

Compound 3, concentration lethal to 50% of the cells: > 500000 nM
Compound 3: no number, only a limit; the forecaster's own chance of this, stated with the estimate: 60%; middle value at least 2.0-fold (0.30 log units) from the limit.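

In this assay compound 3 gives > 500000 nM, which is a limit of the assay and not a number. Compound 1 also has only a limit, and the step from compound 1 to compound 3 cannot be read. The compounds shown leave open whether chloro in place of hydrogen changes how much compound is tolerated.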